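This account rests on a few compounds, and the source may have more. Where it says the series, first, only, none or still open, it means among the compounds named here.

Compound 3 `COc1cc(-c2nn(-c3cccc(NC(=O)Nc4cccc(C(F)(F)F)c4)c3)cc2-c2ccncc2)ccc1Cl` is the only one of the three measured compounds with a number in a functional assay on HCT-15 cells (Homo sapiens) for inhibition, read by sulforhodamine B assay, with a stated time of 48 h; a higher number here means a weaker inhibitor of growth, a lower number a stronger inhibitor of growth: compound 3 gives 5420 nM. Compound 1 `COc1cc(-c2nn(-c3cccc(NC(=O)c4cccc(C(F)(F)F)c4)c3)cc2-c2ccncc2)ccc1Cl` reaches only a limit in this assay, namely > 50000 nM. Compound 2 `COc1cc(-c2nn(-c3cccc(NC(=O)Nc4ccc(Cl)c(Cl)c4)c3)cc2-c2ccncc2)ccc1Cl` likewise reaches only a limit, namely > 50000 nM. The steps of an at least 9.2-fold lower number from compound 1 to compound 3 (0.96 log units; beyond the scatter) and an at least 9.2-fold lower number from compound 2 to compound 3 (0.96 log units; beyond the scatter) are both read against that limit (the limit of > 50000 nM in this assay, at which 2 of the 3 values shown sit). Compound 4 `COc1cc(-c2nn(-c3cccc(NC(=O)c4ccc(Cl)c(C(F)(F)F)c4)c3)cc2-c2ccncc2)ccc1Cl` differs from compound 3 by 4-chloro-3-(trifluoromethyl)phenyl in place of (3-(trifluoromethyl)phenyl)amino on a carbonyl carbon. Compound 1 is the closest measured case, with 3-(trifluoromethyl)phenyl on the carbonyl carbon, and the step of an at least 9.2-fold lower number from compound 1 to compound 3 (0.96 log units; beyond the scatter) covers much the same change read the other way, so compound 4 is expected to move toward a higher number, by a 5.5-fold higher number from compound 3 to compound 4 (0.74 log units; beyond the scatter). Compound 4 is therefore estimated at 30000 nM, within 8000 nM to 100000 nM, with a fair chance that it again meets only the limit.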

Compound 4, concentration for total growth inhibition: > 32500 nM
Compound 4 gave a limit, no number; the forecaster's own chance of this, stated with the estimate: 55%; middle value at least 1.0-fold (0.03 log units) away from the limit.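

In this assay, 4-chloro-3-(trifluoromethyl)phenyl in place of (3-(trifluoromethyl)phenyl)amino on a carbonyl carbon gives an at least 5.9-fold higher number from compound 3 to compound 4 (0.77 log units; beyond the scatter), and this step is read against a limit, not a number: the limit of > 32500 nM in this assay, at which 1 of the 4 values shown sits. Compound 4 carries chloro where compound 1 carries hydrogen, yet it also reaches only a limit, so chloro on this aromatic carbon restores no measurable number. The steps from compound 1 and from compound 2 to compound 4 cannot be read, with limits at both ends.

On these data alone, the true size of the step to compound 4 stays open. So does whether a piperidine or a methylamino group on the carbonyl carbon would give a number in this assay.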